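Dimethylamino Substitution on a Shared Core: Expected Cytotoxicity

The compounds below may be only part of what the source reports. "The series", "measured", "known", "first", "only" and "open" are said of these compounds alone.

Two compounds of one shared core have been examined in a functional assay on HSC-4 cells (Homo sapiens) for cytotoxicity, with a stated time of 24 h; on this read-out higher numbers stand for lower toxicity in this test and lower numbers for higher toxicity in this test. Compound 1 `COc1cc(/C=C2\CCC/C(=C\c3ccccc3[N+](=O)[O-])C2=O)cc(OC)c1OC` gives 6500 nM in this assay. Compound 2 `O=C1/C(=C/c2ccccc2)CCC/C1=C\c1cccc([N+](=O)[O-])c1` gives 2400 nM in this assay, the lowest of the two numbers, with compound 1 as its nearest neighbour at a number that lies beyond the usual scatter. The two compounds differ in more than one place, so their pair shows only what these two values show.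

Compound 3 `CN(C)c1ccc(/C=C2\CCC/C(=C\c3cccc([N+](=O)[O-])c3)C2=O)cc1` has not yet been measured in this assay. It differs from compound 2 in a single place: dimethylamino in place of hydrogen on an aromatic carbon. The change sits on an aromatic carbon of a six-membered aromatic ring of carbon only, para to a large group, and read one bond further out it is phenyl to 4-(dimethylamino)phenyl.

Going by the values given here, no step between measured compounds points the way for this change. The account therefore expects only a small step of a 1.3-fold lower number from compound 2 to compound 3 (0.12 log units; within the scatter), toward a somewhat lower number, and one that may well remain within the scatter. Compound 3 is estimated at 1800 nM in this assay, with a range from 600 nM to 6000 nM.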

Compound 3, half-maximal cytotoxic concentration: 71000 nM
Estimate against measurement, compound 3: 39-fold (1.60 log units) below; the whole stated range lies below it.
By their numbers in this assay, from the lowest: compound 2; then compound 1; then compound 3.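

The result shows that this place on the shared core is not indifferent to substitution. In this assay, going by these compounds alone, putting dimethylamino in place of hydrogen on this aromatic carbon, para to a large group, gives a 30-fold higher number from compound 2 to compound 3 (1.47 log units; beyond the scatter), a large step that on this read-out goes with lower toxicity in this test, and the earlier pair could not show this, as its two compounds differ in more than one place and offered no single-change step. Nothing measured here bears on the reason for a step of this size, so the data give its size and direction but no explanation.

Going by these compounds, what remains open is whether the step belongs to dimethylamino in particular or would follow from other groups on this carbon, such as a primary amine, a carboxylic acid or a longer chain. One change on one pair also leaves open whether dimethylamino at this place would give a step of similar size and direction with a different substitution on the other aromatic ring of the shared core.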